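A few compounds are considered here, and "the series" means these few. Any claim that something is new, unique, unknown or untested is made for them only; others in the source may bear on it.

Measured compounds:
Compound 1, `CCCCCCCCCCCCCC[S+](C)[O-]`, gives 10000 nM in an assay for inhibition of alcohol dehydrogenase (Equus caballus); on this read-out higher numbers stand for weaker inhibition and lower numbers for stronger inhibition.
Compound 2, `CC(C)(C)CC(N)=O`, gives 150000 nM in this assay.

Compound 2 stands at the highest of the two numbers seen so far; its nearest neighbour, compound 1, sits at a markedly lower number, a gap beyond the usual scatter. The two differ in far more than one place, so their values only show where each stands and nothing of what any single change does.

Compound 3, `CC(C)CC(N)=O`, is not yet measured. Set against compound 2 it shows (hydrogen in place of methyl on a saturated chain carbon bound to three saturated chain carbons), a hydrogen in place of methyl on a saturated chain carbon bound to three saturated chain carbons. Among the compounds with values here, no measured pair isolates such a change, so there is no recorded step to lean on. In this assay the step from compound 2 to compound 3 is expected to be a 1.3-fold higher number from compound 2 to compound 3 (0.12 log units; within the scatter), a small drift toward a higher number, if any. For compound 3 the estimate is 200000 nM, within 60000 nM to 700000 nM.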

Compound 3, inhibition constant: 20000 nM
For compound 3 the middle estimate is 10-fold (1.00 log units) above the measured one, and the stated range ends above it.
By their numbers in this assay, from the lowest: compounds 1 and 3 (each within the scatter of the next); then compound 2.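

Hydrogen in place of methyl on a saturated chain carbon bound to three saturated chain carbons gives, in this assay, a 7.5-fold lower number from compound 2 to compound 3 (0.88 log units; beyond the scatter), the first change in a single place to be read here. This position is therefore not indifferent to the change: losing the methyl goes with a lower number, which on this read-out stands for stronger inhibition. Nothing at hand bears on what lies behind this step, so it stands as an observation alone.

Only this one replacement at this carbon is shown, so it remains open how an ethyl or a hydroxyl there would move the number. From the compounds shown here alone, it is also open whether the step would hold in a compound with a carboxylic acid in place of the amide, or with a longer chain.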